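The source may hold more compounds than are shown below. What is called first, only, known or untested is meant among the compounds shown, and "the series" means these compounds.

In a functional assay on PANC-1 cells (Homo sapiens) for cytotoxicity, read by MTT assay, with a stated time of 72 h (a lower number here means a stronger inhibitor, a higher number a weaker inhibitor), compound 1 `COc1cc2c(c(OC)c1OC)-c1cc3cc(CO)oc3cc1C(O)CC2` gives 16 nM and compound 2 `COc1cc2c(c(OC)c1OC)-c1cc3cc(C(C)O)oc3cc1C(O)CC2` gives 30 nM, so these two cannot be told apart. Compound 3 `COc1cc2c(c(OC)c1OC)-c1cc3cc(CCO)oc3cc1C(O)CC2` has the same atoms as compound 2, joined differently: 2-hydroxyethyl in place of 1-hydroxyethyl on an aromatic carbon, with 2-hydroxyethyl in place of 1-hydroxyethyl on an aromatic carbon. Among the compounds with values here, the one measured step that bears on this change is a 1.9-fold higher number from compound 1 to compound 2 (0.27 log units; within the scatter), so no step beyond the scatter is expected in this assay. The expected change is a 1.4-fold lower number from compound 2 to compound 3 (0.13 log units; within the scatter). The estimate for compound 3 is 22 nM, with an expected range from 8 nM to 60 nM.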

Compound 3, half-maximal inhibitory concentration: 400 nM
For compound 3 the middle estimate is 18-fold (1.26 log units) below the measured one, and the stated range ends below it.
By their numbers in this assay, from the lowest: compounds 1 and 2 (each within the scatter of the next); then compound 3.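

At this place on the five-membered aromatic ring, next to the ring oxygen, the arrangement of the same atoms matters: 2-hydroxyethyl in place of 1-hydroxyethyl gives a 13-fold higher number from compound 2 to compound 3 (1.12 log units; beyond the scatter) in this assay. The step of a 25-fold higher number from compound 1 to compound 3 (1.40 log units; beyond the scatter) is also large, so compound 3, with its hydroxy one carbon further out, stands apart from the two compounds that carry it on the carbon bound to the ring. Nothing available explains why this shift counts for so much. Still open, going by these compounds, is whether a longer chain, such as 3-hydroxypropyl, would give a still higher number. Also open, on these data alone, is whether an amine could stand in for the hydroxy.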